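Adding a second methoxy group to the amide arm: expected outcome

This account rests on a few compounds, and the source may have more. Where it says the series, first, only, none or still open, it means among the compounds named here.

The four compounds here share one core and differ only in the benzamide arm at its far end and in one group on the other end. Compound 1 `CNc1nc(Nc2ccc(C)c([N+](=O)[O-])c2)ncc1C(=O)Nc1cc(NC(=O)c2cccc(OC)c2)ccc1C` and compound 2 `CNc1nc(Nc2ccc(C)c([N+](=O)[O-])c2)ncc1C(=O)Nc1cc(NC(=O)c2cc(OC)cc(OC)c2)ccc1C` are measured in an ADME assay on BaF3 cells (Mus musculus) for antiproliferative activity, read by CellTiter-Glo and CCK-8 assay, with a stated time of 72 h; a higher number here means a weaker inhibitor of growth, a lower number a stronger inhibitor of growth. In this assay compound 1 gives 6310 nM. For compound 2 the assay reports only a limit, > 10000 nM, not a number. The change between them, (methoxy in place of hydrogen on an aromatic carbon), therefore gives an at least 1.5-fold higher number from compound 1 to compound 2 (0.19 log units; that floor lies within the scatter).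

Compound 3 `CNc1nc(Nc2ccc(C)c(N)c2)ncc1C(=O)Nc1cc(NC(=O)c2ccc(OC)cc2)ccc1C` carries a different core part, and the difference between the two cores is not broken down here. For compound 3 the assay again reports only a limit, > 10000 nM. Compound 4 `CNc1nc(Nc2ccc(C)c(N)c2)ncc1C(=O)Nc1cc(NC(=O)c2ccc(OC)c(OC)c2)ccc1C` is not yet measured; it differs from compound 3 by methoxy in place of hydrogen on an aromatic carbon. Within the data shown here, this is the same kind of change as the one from compound 1 to compound 2, though not the same: there the entering methoxy sat meta to a methoxy group, here it sits ortho to a methoxy group.

Compound 3 already sits at the limit of > 10000 nM in this assay, at which 2 of the 3 values shown sit, and the earlier methoxy addition did not lower the number, so compound 4 is expected to stay at or beyond that limit, with an estimated step that the limit leaves unreadable from compound 3 to compound 4. The estimate for compound 4 is 15000 nM, within a range of 8000 nM to 40000 nM, and the assay will most likely again report only a limit.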

Compound 4, concentration for 50% growth inhibition: > 10000 nM
Compound 4: only a limit was reported; the forecaster's own chance of this, stated with the estimate: 85%; the middle value is on the limit's open side.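

In this assay compound 4 gives > 10000 nM, which is a limit and not a number. Compound 3 also stands at a limit, so the step between compound 3 and compound 4 cannot be read. The compounds shown leave open whether the added methoxy changes growth inhibition at all, and how far compound 3 and compound 4 lie beyond the point where the assay stops giving numbers: the limit of > 10000 nM in this assay, at which 3 of the 4 values shown sit.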